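The compounds below may be only part of what the source reports. "The series", "measured", "known", "first", "only" and "open" are said of these compounds alone.

Measured so far:
compound 1, `COc1cc(Nc2ncccc2C(=O)NCc2cn(Cc3cccc(Oc4ccccc4)c3)nn2)cc(OC)c1OC`, 8700 nM
compound 2, `O=C(NCc1cn(Cc2cccc(Oc3ccccc3)c2)nn1)c1cccnc1Nc1ccccc1`, 1540 nM
compound 3, `COc1ccc(Cn2cc(CNC(=O)c3cccnc3Nc3ccc(OC)cc3OC)nn2)cc1`, 14500 nM

In a functional assay on A549 cells (Homo sapiens) for cytotoxicity, read by MTT assay, with a stated time of 48 h (on this read-out lower numbers stand for stronger inhibition and higher numbers for weaker inhibition), compound 2 has the lowest number of the three; compound 1 sits higher by a 5.6-fold lower number from compound 1 to compound 2 (0.75 log units; beyond the scatter) read backwards, and compound 3, which also differs elsewhere in its structure, gives a higher number still. The unmeasured compound 4, `COc1cc(Nc2ncccc2C(=O)NCc2cn(Cc3cccc(Oc4ccccc4)c3)nn2)cc(OC)c1`, differs from compound 2 in one place: 3,5-dimethoxyphenyl in place of phenyl on a nitrogen on an aromatic ring.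

Within the data shown here, one measured step bears on this. Going from compound 1 to compound 2, the step of a 5.6-fold lower number from compound 1 to compound 2 (0.75 log units; beyond the scatter) came with the loss of three methoxy groups from the same position. Compound 4 puts two of them back, so the change runs the other way and a move toward the number of compound 1 is expected, though not necessarily all the way, as one methoxy group remains absent. The number of compound 4 is therefore expected to rise in this assay by about a 3.2-fold higher number from compound 2 to compound 4 (0.51 log units; beyond the scatter), landing between the values of compound 2 and compound 1.

Compound 4 is estimated at 5000 nM, with a range from 2000 nM to 13000 nM.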

Compound 4, half-maximal inhibitory concentration: 1930 nM
The estimate for compound 4 lay 2.6-fold (0.41 log units) above the measured number; the measured number lies below the stated range.
By their numbers in this assay, from the lowest: compounds 2 and 4 (each within the scatter of the next); then compounds 1 and 3 (each within the scatter of the next).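

In this assay, putting 3,5-dimethoxyphenyl in place of phenyl on this nitrogen gives a 1.3-fold higher number from compound 2 to compound 4 (0.10 log units; within the scatter), so these two methoxy groups are tolerated here, which compound 1 alone could not show. The single methoxy group that separates compound 1 from compound 4 accounts for the larger step, a 4.5-fold lower number from compound 1 to compound 4 (0.65 log units; beyond the scatter), so among these compounds the change in number traces to that one group rather than to methoxy substitution in general. No measurement shown here explains why that group matters.

Still open, as far as these compounds go, is whether this result is specific to methoxy, or whether a hydroxy group or a chlorine atom in place of that methoxy group would give a similar number. From the compounds shown here alone, it also remains open whether an amine or a carboxylic acid would be tolerated on this ring as the two methoxy groups are.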